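Cyclopentylsulfanyl replaces trifluoroethoxy on a cytotoxicity-clean core

The compounds below may be only part of what the source reports. "The series", "measured", "known", "first", "only" and "open" are said of these compounds alone.

Compound 2 `Nc1nc(OCC(F)(F)F)c2ncn(/C=C3/CC3(CO)CO)c2n1` has been tested in an ADME assay on Akata cells (Homo sapiens) for cytotoxicity, with a stated time of 7 days; on this read-out lower numbers stand for higher toxicity in this test and higher numbers for lower toxicity in this test. In this assay compound 2 gives > 20000 nM, which is a limit of the assay and not a number. Two related compounds share its core. Compound 1 `CNc1nc(N)nc2c1ncn2/C=C1/CC1(CO)CO` carries a methylamino group in the same place, and in this assay compound 1 gives > 24000 nM, again a limit rather than a number. Compound 3 `CSc1nc(N)nc2c1ncn2/C=C1/CC1(CO)CO` carries a methylsulfanyl group there, and in this assay compound 3 gives > 20000 nM, also a limit. All three values therefore sit at the limit of > 20000 nM in this assay, at which 2 of the 3 values shown sit, or at the limit of > 24000 nM in this assay, at which 1 of the 3 values shown sits, so compound 2 stands at the same limit as compound 3 and cannot be placed above or below compound 1. The steps between them are a step that the two limits leave unreadable from compound 1 to compound 2, a step that the two limits leave unreadable from compound 1 to compound 3 and a step that the two limits leave unreadable from compound 2 to compound 3, none of which has a readable size.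

Compound 4 `Nc1nc(SC2CCCC2)c2ncn(/C=C3/CC3(CO)CO)c2n1` differs from compound 2 by cyclopentylsulfanyl in place of 2,2,2-trifluoroethoxy on an aromatic carbon. The closest measured change is a step that the two limits leave unreadable from compound 2 to compound 3, where a sulfur-linked group also replaced the trifluoroethoxy group; it left no readable step, and so no shift in this assay beyond the scatter is expected, the expected step being a number no higher from compound 2 to compound 4 (the limit leaves the size open). Compound 4 is estimated at 20000 nM, between 7000 nM and 60000 nM.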

Compound 4, half-maximal cytotoxic concentration: > 20000 nM
Compound 4: no number, only a limit; the forecaster's own chance of this, stated with the estimate: 65%; the middle value lies on the limit itself.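

In this assay compound 4 gives > 20000 nM, a limit and not a number, so its steps to compound 1, compound 2 and compound 3 cannot be read. The compounds shown leave open at what concentration any of them becomes toxic in this assay, and whether changing the group on this aromatic carbon alters that.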